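Lengthening the acid chain of a biaryl pyridine ether

This account rests on a few compounds, and the source may have more. Where it says the series, first, only, none or still open, it means among the compounds named here.

Of the compounds shown here, three of a shared core have been measured in an assay for binding affinity to leukotriene B4 receptor 1 (Homo sapiens); on this read-out lower numbers stand for stronger inhibition and higher numbers for weaker inhibition. Compound 1 `COC(=O)CCCCCOc1cc(-c2ccccc2)cc(-c2ccccc2)n1` carries a methyl ester at the end of its chain and gives 100 nM. Compound 3 `O=C(O)CCCCCOc1cc(-c2ccccc2)cc(-c2ccccc2)n1` is the free acid of the same chain; in this assay compound 3 gives 30 nM. Compound 2 `O=C(O)CCCCCOc1cc(-c2ccccc2)cc(-c2ccc(F)cc2)n1` differs from compound 3 only by a fluoro on one of the outer rings, and compound 2 gives 30 nM. Two steps stand out: a 3.3-fold lower number from compound 1 to compound 3 (0.52 log units; beyond the scatter), and no change at the digits printed from compound 2 to compound 3 (within the scatter). Compound 3 thus stands level with compound 2 at the digits shown, the two together giving the lowest numbers of the three, with compound 1 furthest away.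

Compound 4 `O=C(O)CCCCCCOc1cc(-c2ccccc2)cc(-c2ccccc2)n1` keeps the core and the free acid but stretches the chain between the ring oxygen and the acid: carboxymethyl in place of carboxy on a saturated chain carbon, five bonds along the chain from an oxygen on an aromatic ring. Neither measured step touches chain length; one concerns the ester against the acid and the other a ring substituent, so no direct guide exists for this change. The acid itself is kept, which in the step from compound 1 to compound 3 mattered. A step within the scatter is therefore the plainest expectation, written as no change at the digits printed from compound 3 to compound 4 (within the scatter). Compound 4 is expected to give about 30 nM, within a range from 10 nM to 100 nM.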

Compound 4, half-maximal inhibitory concentration: 15 nM
Estimate against measurement, compound 4: 2.0-fold (0.30 log units) above, and the stated range covers the measured number.
By their numbers in this assay, from the lowest: compounds 4, 2 and 3 (each within the scatter of the next); then compound 1.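

Within the scatter of this assay, the free acid tolerates one more chain carbon at this position: carboxymethyl in place of carboxy gives a 2.0-fold lower number from compound 3 to compound 4 (0.30 log units; within the scatter) and so leaves compound 3 and compound 4 indistinguishable on this read-out. Among these compounds, the earlier steps changed the end group or a ring substituent, so this is the first measured look at chain length, and at this single step it does not separate the two acids. The ester comparison holds on the stretched chain as well, with a 6.7-fold lower number from compound 1 to compound 4 (0.82 log units; beyond the scatter) clearing the scatter, although that step changes the chain end and its length together. Nothing measured here offers an explanation for how the longer chain is accommodated.

From the compounds shown here alone, a still longer chain and a shorter one remain open, so these compounds cannot show whether the acid chain has a best length or how far it can be stretched. Also open, going by these compounds, are other groups at the chain end, such as a primary amide or a sulfonic acid, and whether a fluoro on the outer ring behaves the same way on the longer chain.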